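The compounds below may be only part of what the source reports. "The series", "measured", "known", "first", "only" and "open" are said of these compounds alone.

Measured so far:
- compound 1, `CC[C@H](C)[C@H](N)CN(C(=O)[C@@H]1C[C@H]1c1ccccc1)c1ccc(-c2ccc(C(F)(F)F)cc2)cc1`: 340 nM
- compound 2, `CC[C@H](C)[C@H](N)CN(C(=O)[C@@H]1C[C@H]1c1ccccc1)c1ccc(-c2ccc(CO)cc2)cc1`: 1100 nM
- compound 3, `CC[C@H](C)[C@H](N)CN(C(=O)[C@@H]1C[C@H]1c1ccccc1)c1ccc(-c2ccc(C(=O)N(C)C)cc2)cc1`: 980 nM

All three compounds share one core and differ only in the group on the outer aromatic ring. In a functional assay for agonist activity at G protein-coupled receptor 88 (Homo sapiens), read by HTRF and cAMP accumulation (a higher number here means that more compound is needed for the effect, a lower number that less compound is needed), compound 1 gives 340 nM, the lowest number of the set. Compound 3 stands second highest: it sits a small distance from compound 2 (a 1.1-fold lower number from compound 2 to compound 3 (0.05 log units; within the scatter)) and further from compound 1 (a 2.9-fold higher number from compound 1 to compound 3 (0.46 log units; beyond the scatter)).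

Compound 4, `CC[C@H](C)[C@H](N)CN(C(=O)[C@@H]1C[C@H]1c1ccccc1)c1ccc(-c2ccc(CN(C)C)cc2)cc1`, is not yet measured. It differs from compound 3 in one place: (dimethylamino)methyl in place of dimethylcarbamoyl on an aromatic carbon. The steps seen so far bear on this only loosely. Replacing trifluoromethyl cost a modest amount in both directions tried (a 3.2-fold higher number from compound 1 to compound 2 (0.51 log units; beyond the scatter); a 2.9-fold higher number from compound 1 to compound 3 (0.46 log units; beyond the scatter)), while swapping hydroxymethyl for dimethylcarbamoyl changed little (a 1.1-fold lower number from compound 2 to compound 3 (0.05 log units; within the scatter)). Going by the values given here, no step directly covers the loss of the carbonyl. The expectation is therefore a step from compound 3 to compound 4 of roughly a 1.0-fold higher number from compound 3 to compound 4 (0.01 log units; within the scatter), not clearly beyond the scatter. Compound 4 is estimated at 1000 nM, with a range from 300 nM to 3500 nM.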

Compound 4, half-maximal effective concentration: 460 nM
The estimate for compound 4 lay 2.2-fold (0.34 log units) above the measured number; the measured number falls inside the stated range.
By their numbers in this assay, from the lowest: compounds 1 and 4 (each within the scatter of the next); then compounds 3 and 2 (each within the scatter of the next).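

On this aromatic carbon, the earlier replacements of trifluoromethyl had only raised the number in this assay, but (dimethylamino)methyl brings it back down: a 2.1-fold lower number from compound 3 to compound 4 (0.33 log units; beyond the scatter) when it replaces dimethylcarbamoyl, and a 2.4-fold lower number from compound 2 to compound 4 (0.38 log units; beyond the scatter) when dimethylamino replaces the hydroxy of hydroxymethyl. The remaining step, a 1.4-fold higher number from compound 1 to compound 4 (0.13 log units; within the scatter), lies within the scatter, so among these compounds trifluoromethyl is not the only group that gives a number in this range. Nothing measured here explains why (dimethylamino)methyl differs from the other two replacements.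

These compounds leave open whether the two methyl groups on the nitrogen matter, which a plain aminomethyl group would test. They also leave open how a longer chain carrying the dimethylamino group, or a carboxylic acid at this place, would compare.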